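A few compounds are considered here, and "the series" means these few. Any claim that something is new, unique, unknown or untested is made for them only; others in the source may bear on it.

Working notes on the series, read in a functional assay on MOLT-4 cells (Homo sapiens) for antiproliferative activity, with a stated time of 48 h; a higher number here means a weaker inhibitor, a lower number a stronger inhibitor. Of the compounds shown here, three have numbers so far: compound 1 (`C=C(Br)C(=O)Nc1ccc(C(=O)/C=C/c2ccccc2OC)cc1`) gives 240 nM, compound 3 (`C=C(Br)C(=O)Nc1ccc(C(=O)/C=C/c2ccc(OC)c(OC)c2OC)cc1`) gives 680 nM and compound 2 (`C=C(Br)C(=O)Nc1ccc(C(=O)/C=C/c2ccc(OC)cc2OC)cc1`) gives 1500 nM. Compound 2 has the highest number of the three, and both of its gaps lie beyond the scatter, so it is the weakest inhibitor measured so far.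

Compound 4 (`COc1ccc(/C=C/C(=O)c2ccc(N)cc2)c(OC)c1`) is unmeasured and departs from compound 2 as follows: hydrogen in place of (1-bromoethenyl)carbonyl on a nitrogen on an aromatic ring. Hydrogen takes the place of (1-bromoethenyl)carbonyl on a nitrogen on an aromatic ring.

The measured steps are a 6.3-fold higher number from compound 1 to compound 2 (0.80 log units; beyond the scatter) and a 2.2-fold lower number from compound 2 to compound 3 (0.34 log units; beyond the scatter). Both are modest, and both are methoxy in place of hydrogen on an aromatic carbon. Neither touches the nitrogen. All three measured compounds keep the (1-bromoethenyl)carbonyl group, so the data hold no direct test of its loss and offer only a scale for comparison. Removing this shared group is a larger structural change than one methoxy, so a step somewhat larger than the bigger measured one is expected, towards a higher number. The expected step is a 10-fold higher number from compound 2 to compound 4 (1.00 log units; beyond the scatter), and this is a loose estimate. Compound 4 is estimated at 15000 nM, with an expected range of 4000 nM to 60000 nM.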

Compound 4, half-maximal inhibitory concentration: 20000 nM
Compound 4: the middle estimate sits 1.3-fold (0.12 log units) below what was measured; measured number inside the range.
By their numbers in this assay, from the lowest: compound 1; then compound 3; then compound 2; then compound 4.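

In this assay, for the compounds shown here, replacing the (1-bromoethenyl)carbonyl group on the nitrogen with hydrogen gives a 13-fold higher number from compound 2 to compound 4 (1.12 log units; beyond the scatter), the first direct reading at this position, as both earlier steps were methoxy changes on an aromatic carbon. This step is classed as large, whereas a 6.3-fold higher number from compound 1 to compound 2 (0.80 log units; beyond the scatter) and a 2.2-fold lower number from compound 2 to compound 3 (0.34 log units; beyond the scatter) are both classed as modest, so within these compounds the loss of the whole group on the nitrogen registers more strongly than either methoxy change, although compound 4 still gives a number, 20000 nM. No available evidence bears on the reason for this loss in activity.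

Going by these compounds alone, the reading rests on the single pair of compound 2 and compound 4, so it remains open whether the same replacement would give a step of similar size in the settings of compound 1 or compound 3. Going by these compounds, it also remains open which part of the departed group carries the difference, a question that a plain acetyl group, an unbrominated propenoyl group or a chlorine in place of the bromine on the nitrogen substituent could help to separate.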